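Anilide series: heteroaryl replacing 2-bromophenyl on the amide nitrogen

The compounds below may be only part of what the source reports. "The series", "measured", "known", "first", "only" and "open" are said of these compounds alone.

Measured so far:
compound 1 `COc1ccc(C(=O)Nc2ccccc2Br)cc1OC1CCCC1`: 130 nM
compound 2 `COc1ccc(C(=O)Nc2ccccc2Cl)cc1OC`: 650 nM
compound 3 `COc1ccc(C(=O)Nc2c(Cl)c(F)nc(F)c2Cl)cc1OC1CCCC1`: 20 nM

In an assay on isolated protein for inhibition of phosphodiesterase 4A (Sus scrofa) (a lower number here means a stronger inhibitor, a higher number a weaker inhibitor), compound 1 gives 130 nM and stands second highest of the three numbers. Compound 2 gives 650 nM, a higher number beyond the scatter, and compound 3 gives 20 nM, a lower number beyond the scatter. For the measured compounds named here, no single-change step between measured compounds is at hand.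

Compound 4 `COc1ccc(C(=O)Nc2c(C)nsc2C#N)cc1OC1CCCC1` is compound 1 with a change on the amide nitrogen: 5-cyano-3-methyl-1,2-thiazol-4-yl in place of 2-bromophenyl on an amide-type nitrogen. Compound 3 shows that a ring with hetero atoms and substituents on both sides of the attachment can sit at a lower number than compound 1, so a modest downward step from compound 1 to compound 4 in this assay is expected, though its size is uncertain. Compound 4 is therefore estimated at 50 nM, range 15 nM to 170 nM, meaning an expected step of a 2.6-fold lower number from compound 1 to compound 4 (0.41 log units; beyond the scatter).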

Compound 4, half-maximal inhibitory concentration: 200 nM
The estimate for compound 4 lay 4.0-fold (0.60 log units) below the measured number; measured number outside the range, above it.
By their numbers in this assay, from the lowest: compound 3; then compounds 1 and 4 (each within the scatter of the next); then compound 2.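

In this assay, 5-cyano-3-methyl-1,2-thiazol-4-yl in place of 2-bromophenyl on the amide-type nitrogen gives a 1.5-fold higher number from compound 1 to compound 4 (0.19 log units; within the scatter). This single-place comparison shows that this position tolerates a five-membered aromatic ring with 2 hetero atoms, so a six-membered aromatic ring of carbon only is not required here. No measurement at hand accounts for this result. The step cannot separate the contribution of the ring from those of its nitrile and methyl groups. Also open, on these data alone, is how a carboxylic acid in place of the nitrile would read in this assay.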